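Pyrrol-1-yl in Place of Cyclohexyl: An Expected Limit

This account rests on a few compounds, and the source may have more. Where it says the series, first, only, none or still open, it means among the compounds named here.

Of the compounds shown here, two have been measured in a functional assay on SUP-B15 cells (Homo sapiens) for antiproliferative activity, with a stated time of 72 h; a lower number here means that less compound is needed, a higher number that more compound is needed for the effect. Compound 1, `COc1ccc(-c2cc(=O)c3c(OC)cc(OC)cc3n2S(=O)(=O)c2ccc(C)c([N+](=O)[O-])c2)cc1`, reaches only the limit of the method, and in this assay compound 1 gives > 51700 nM. Compound 2, `COc1cc(OC)c2c(=O)cc(C(=O)Nc3ccc(C4CCCCC4)cc3)[nH]c2c1`, likewise stops at a limit, and in this assay compound 2 gives > 43100 nM. Thus both values shown are limits rather than numbers, as noted in the limit of > 43100 nM in this assay, at which 1 of the 2 values shown sits, and (the limit of > 51700 nM in this assay, at which 1 of the 2 values shown sits), so no measured step between the two can be stated, and compound 2 stands at the edge of what the method resolves.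

The untested compound 3, `COc1cc(OC)c2c(=O)cc(C(=O)Nc3ccc(-n4cccc4)cc3)[nH]c2c1`, keeps the core of compound 2 and changes one place: 1H-pyrrol-1-yl in place of cyclohexyl on an aromatic carbon. Within the data shown here, with no measured step to lean on, no shift beyond the usual scatter is expected in this assay, and the step from compound 2 to compound 3 is estimated as a step that the limit leaves unreadable from compound 2 to compound 3. Compound 3 is therefore expected to give about 45000 nM, with a range from 15000 nM to 100000 nM, most likely again reported as a limit.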

Compound 3, half-maximal effective concentration: > 77000 nM
Compound 3 was reported as a limit (the forecaster's own chance of this, stated with the estimate: 70%); middle value at least 1.7-fold (0.23 log units) away from the limit.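

In this assay, among these compounds, compound 2 and compound 3 both stop at a limit of the method, so no step between them can be read. The compounds shown leave open whether any of these structures would give a measured number rather than a limit.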